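Thiophen-2-yl in place of 2-methoxyphenyl on the shared core

A few compounds are considered here, and "the series" means these few. Any claim that something is new, unique, unknown or untested is made for them only; others in the source may bear on it.

Measured compounds, in a functional assay on A-375 cells (Homo sapiens) for antiproliferative activity, read by MTT assay, with a stated time of 48 h; on this read-out lower numbers stand for stronger inhibition of growth and higher numbers for weaker inhibition of growth:
Compound 1 `S=C(Nc1ccccc1)N1N=C(c2ccc(Cl)cc2)CC1c1ccc2c(c1)OCCO2` gives 195000 nM.
Compound 2 `S=C(Nc1ccccc1)N1N=C(c2ccccc2Br)CC1c1ccc2c(c1)OCCO2` gives > 200000 nM, which is a limit of the assay and not a number.
Compound 3 `COc1ccccc1C1=NN(C(=S)Nc2ccccc2)C(c2ccc3c(c2)OCCO3)C1` gives 20300 nM.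

Compound 3 has the lowest of the two numbers shown, and the gap to the nearest number is a 9.6-fold lower number from compound 1 to compound 3 (0.98 log units; beyond the scatter). Compound 2 sits at the limit of > 200000 nM in this assay, at which 1 of the 3 values shown sits. The unmeasured compound 4 `S=C(Nc1ccccc1)N1N=C(c2cccs2)CC1c1ccc2c(c1)OCCO2` differs from compound 3 in one place: thiophen-2-yl in place of 2-methoxyphenyl on a carbon with a double bond to nitrogen. Among the measured compounds shown here, the steps that bear on this position are a 9.6-fold lower number from compound 1 to compound 3 (0.98 log units; beyond the scatter) and an at least 9.8-fold lower number from compound 2 to compound 3 (0.99 log units; beyond the scatter), both lowering the number as 2-methoxyphenyl arrived there. Replacing it with thiophen-2-yl is therefore expected to raise the number in this assay by a step of a 3.0-fold higher number from compound 3 to compound 4 (0.47 log units; beyond the scatter). Compound 4 is estimated at 60000 nM, with a range from 15000 nM to 200000 nM.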

Compound 4, concentration for 50% growth inhibition: 121000 nM
The estimate for compound 4 lay 2.0-fold (0.30 log units) below the measured number; the range from low to high includes it.
By their numbers in this assay, from the lowest: compound 3; then compounds 4 and 1 (each within the scatter of the next). At a limit, above all of these: compound 2.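

In this assay, 2-methoxyphenyl at this carbon now stands apart from a five-membered aromatic ring as well as from the halogen-bearing phenyl groups, with a 6.0-fold higher number from compound 3 to compound 4 (0.78 log units; beyond the scatter). Thiophen-2-yl and 4-chlorophenyl cannot be told apart here, with a 1.6-fold lower number from compound 1 to compound 4 (0.21 log units; within the scatter), and against 2-bromophenyl the result is an at least 1.6-fold lower number from compound 2 to compound 4 (0.21 log units; that floor lies within the scatter). Compound 2 stands at a limit and not a number: the limit of > 200000 nM in this assay, at which 1 of the 4 values shown sits.

As far as these compounds go, it remains open whether unsubstituted phenyl, 2-hydroxyphenyl or 2-aminophenyl at this carbon would keep the low number of compound 3.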